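Notes on compound 4, a carbamoyl analogue of compound 3

This account rests on a few compounds, and the source may have more. Where it says the series, first, only, none or still open, it means among the compounds named here.

compound 1 `O=C(Nc1cccc(-n2cc(-c3ccncc3)c(-c3ccc(Cl)c(O)c3)n2)c1)Nc1cccc(C(F)(F)F)c1`: 7260 nM in a functional assay on HCC 2998 cells (Homo sapiens) for inhibition, read by sulforhodamine B assay, with a stated time of 48 h; on this read-out lower numbers stand for stronger inhibition of growth and higher numbers for weaker inhibition of growth
compound 2 `COc1cc(-c2nn(-c3cccc(NC(=O)Nc4cc(C(F)(F)F)cc(C(F)(F)F)c4)c3)cc2-c2ccncc2)ccc1Cl`: 931 nM
compound 3 `COc1cc(-c2nn(-c3cccc(NC(=O)c4cccc(C(F)(F)F)c4)c3)cc2-c2ccncc2)ccc1Cl`: 2240 nM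

Compound 3 stands second highest of the three numbers in this assay. The nearest is compound 2, whose number is lower by a margin beyond the scatter; the furthest is compound 1, higher by a margin beyond the scatter. Within the data shown here, no pair of the measured compounds differs in one place, so no single step can be read off directly.

Compound 4 `COc1cc(-c2nn(-c3cccc(NC(=O)Nc4ccc(Cl)c(Cl)c4)c3)cc2-c2ccncc2)ccc1Cl` is yet to be measured. It differs from compound 3 by (3,4-dichlorophenyl)amino in place of 3-(trifluoromethyl)phenyl on a carbonyl carbon; read one bond further out, the change is (3-(trifluoromethyl)phenyl)carbonyl to (3,4-dichlorophenyl)carbamoyl. Among the measured compounds shown here, no measured step covers this change, so the expectation rests on the standing of the series: compound 2 gives 931 nM and compound 1 gives 7260 nM, a modest spread. A moderate step toward a lower number is expected, since the lowest number in the set comes from a carbamoyl-bearing compound. Compound 4 is estimated at 1300 nM, within 500 nM to 3200 nM. The expected step is a 1.7-fold lower number from compound 3 to compound 4 (0.24 log units; within the scatter).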

Compound 4, concentration for 50% growth inhibition: 1560 nM
Beside the measured number, compound 4's estimate is 1.2-fold (0.08 log units) below it; low and high end bracket the measured number.
By their numbers in this assay, from the lowest: compounds 2, 4 and 3 (each within the scatter of the next, the first and the last beyond it); then compound 1.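

In this assay the series now has its first step in one place, a 1.4-fold lower number from compound 3 to compound 4 (0.16 log units; within the scatter), with (3,4-dichlorophenyl)amino in place of 3-(trifluoromethyl)phenyl on a carbonyl carbon. The change brings in one hydrogen-bond donor and replaces the ring substitution, yet compound 3 and compound 4 cannot be told apart here, so this position accepts the (3,4-dichlorophenyl)carbamoyl form without a separable shift in growth inhibition. No supporting measurement bears on this result.

Still open, from the compounds shown here alone, is how much of the step belongs to the amino link and how much to the chlorines, since the two changes arrive together. Also open, going by these compounds, is how this assay would read with a carboxylic acid or a dimethylamino group on this ring.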